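Swapping Methyl for Fluoro on a Pendant Phenyl Ring

The source may hold more compounds than are shown below. What is called first, only, known or untested is meant among the compounds shown, and "the series" means these compounds.

Compound 1 `COc1cc2c(Oc3ccc(NC(=O)c4cc(-c5ccccc5C)ccn4)cc3F)ccnc2cc1OCCCN1CCN(C)CC1` and compound 2 `COc1cc2c(Oc3ccc(NC(=O)c4cc(-c5ccccc5F)ccn4)cc3F)ccnc2cc1OCCCN1CCN(C)CC1` share one core, while compound 3 `COc1cc2c(Oc3ccc(NC(=O)c4nccc(-c5ccc(C)cc5)n4)cc3F)ccnc2cc1OCCCN1CCCCC1` and compound 4 `COc1cc2c(Oc3ccc(NC(=O)c4nccc(-c5ccc(F)cc5)n4)cc3F)ccnc2cc1OCCCN1CCCCC1` share another; the difference between the two cores is not broken down here. In a functional assay on MKN-45 cells (Homo sapiens) for cytotoxicity, read by MTT assay, with a stated time of 72 h (on this read-out lower numbers stand for stronger inhibition and higher numbers for weaker inhibition), compound 1 gives 240 nM, and compound 2 gives 150 nM. The change from compound 1 to compound 2 is fluoro in place of methyl on an aromatic carbon and it produced a 1.6-fold lower number from compound 1 to compound 2 (0.20 log units; within the scatter). In this assay compound 3 gives 580 nM, the highest number among the three measured compounds. Compound 4 carries the same kind of change, made on the other core: fluoro in place of methyl on an aromatic carbon. The surroundings of the place differ, though: in the first pair the fluoro sits ortho to a large group, in the second pair para to a large group. Because the earlier step measured a 1.6-fold lower number from compound 1 to compound 2 (0.20 log units; within the scatter), a step of similar, modest size is expected here: a 1.4-fold lower number from compound 3 to compound 4 (0.14 log units; within the scatter). Compound 4 is therefore estimated at 420 nM, with the likely range running from 200 nM to 900 nM.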

Compound 4, half-maximal inhibitory concentration: 930 nM
Estimate against measurement, compound 4: 2.2-fold (0.35 log units) below; measured number outside the range, above it.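

In this assay, fluoro in place of methyl, para to a large group, gives a 1.6-fold higher number from compound 3 to compound 4 (0.21 log units; within the scatter), so this step, like the earlier one, is no larger than the ordinary variation between repeated measurements. The two steps are printed with opposite directions, yet they cannot be told apart: the same change on two cores in this assay, a 1.6-fold lower number (0.20 log units; within the scatter) from compound 1 to compound 2 and a 1.6-fold higher number (0.21 log units; within the scatter) from compound 3 to compound 4, 2.6-fold (0.41 log units) apart, within the scatter of two such steps. This fits a change that stays small on both cores, with its direction unresolved, but it does not show that the change acts identically on both, and the fluoro also sits in a different place on the ring in each pair, while two pairs cannot speak for any further core.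

Still open, as far as these compounds go, is how other groups at this place would behave, such as chloro, methoxy or an amine, and whether any of them would move the number by more than the usual scatter. Also open, from the compounds shown here alone, is whether a longer chain in place of the methyl would give a step that reads the same on both cores.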